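This account rests on a few compounds, and the source may have more. Where it says the series, first, only, none or still open, it means among the compounds named here.

Compound 1 `COc1cc(-c2ccnc3cc(-c4ccc(Cl)cc4)nn23)cc(OC)c1OC`: 3070 nM
Compound 2 `COc1cc(-c2ccnc3cc(-c4ccccc4)nn23)cc(OC)c1OC`: 208 nM
Compound 3 `COc1ccc(-c2cc3nccc(-c4cc(OC)c(OC)c(OC)c4)n3n2)cc1`: 376 nM

In a functional assay on A549 cells (Homo sapiens) for inhibition, read by CCK-8 assay, with a stated time of 48 h (a higher number here means a weaker inhibitor, a lower number a stronger inhibitor), compound 3 gives 376 nM. That is within the scatter of compound 2, at 208 nM, and well under compound 1, at 3070 nM.

Compound 4 `COc1cc(-c2ccnc3cc(-c4ccc(C(C)(C)C)cc4)nn23)cc(OC)c1OC` makes one change to compound 3: tert-butyl in place of methoxy on an aromatic carbon, para to a large group (tert-butyl in place of methoxy on an aromatic carbon). In other words, 4-methoxyphenyl becomes 4-(tert-butyl)phenyl.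

All three measured steps change a group at this same place. Swapping chloro for hydrogen gives a 15-fold lower number from compound 1 to compound 2 (1.17 log units; beyond the scatter), and swapping chloro for methoxy gives an 8.2-fold lower number from compound 1 to compound 3 (0.91 log units; beyond the scatter). Both are clear changes. Swapping hydrogen for methoxy gives a 1.8-fold higher number from compound 2 to compound 3 (0.26 log units; within the scatter), which is within the scatter. So the group here can matter a great deal, but no measured compound carries tert-butyl, and the size of the step remains uncertain.

The one other substituent tried here, chloro in compound 1 at 3070 nM, sits well above compound 3, so a moderate rise seems more likely than a fall. The expected change is a 2.7-fold higher number from compound 3 to compound 4 (0.42 log units; beyond the scatter), towards weaker inhibition. For compound 4 the estimate is 1000 nM, with an expected range from 250 nM to 4000 nM.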

Compound 4, half-maximal inhibitory concentration: > 10000 nM
Compound 4 gave a limit, no number; the forecaster's own chance of this, stated with the estimate: 5%; at least 10-fold (1.00 log units) between middle value and limit.
By their numbers in this assay, from the lowest: compounds 2 and 3 (each within the scatter of the next); then compound 1. At a limit, above all of these: compound 4.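

In this assay, compound 4 gives only a limit, not a number: the limit of > 10000 nM in this assay, at which 1 of the 4 values shown sits. The steps to it are therefore minimum sizes: an at least 26-fold higher number from compound 3 to compound 4 (1.42 log units; beyond the scatter), an at least 48-fold higher number from compound 2 to compound 4 (1.68 log units; beyond the scatter) and an at least 3.2-fold higher number from compound 1 to compound 4 (0.51 log units; beyond the scatter), so even the smallest of them, measured against the chloro compound, lies beyond the scatter. The earlier compounds shown here showed that chloro could cost much compared with hydrogen or methoxy, while hydrogen and methoxy stayed within the scatter of each other; the tert-butyl result adds that 4-(tert-butyl)phenyl gives a far weaker reading than either of those two, and weaker than the chloro compound as well, so this place accepts only some groups and the swap of methoxy for tert-butyl is a severe one.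

What remains open is how the number moves with groups that lie in character between those shown, such as an ethyl or isopropyl group, a fluoro atom, or an amine or carboxylic acid at the same place. From the compounds shown here alone, the true value of compound 4 also stays unknown, so the full size of each of its steps cannot be stated.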